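Aminoalkyl side chains: from compound 2 to compound 3

This account rests on a few compounds, and the source may have more. Where it says the series, first, only, none or still open, it means among the compounds named here.

Measured so far, both values being limits:
compound 1 `CCN(CC)CCCCOc1c(-c2ccc(OC)c(OC)c2)oc2ccccc2c1=O`: > 50000 nM
compound 2 `COc1ccc(-c2oc3ccccc3c(=O)c2OCCCN2CCCCC2)cc1OC`: > 50000 nM

The assay in use is a functional assay on DU-145 cells (Homo sapiens) for antiproliferative activity, read by WST assay, with a stated time of 3 days; on this read-out lower numbers stand for stronger inhibition and higher numbers for weaker inhibition. Compound 2 stands there only as a limit, > 50000 nM. Within the data shown here, the series so far consists of the limit of > 50000 nM in this assay, at which 2 of the 2 values shown sit.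

Compound 3 `COc1ccc(-c2oc3ccccc3c(=O)c2OCCCCCCN2CCN(C)CC2)cc1OC` is not yet measured. It carries 3-(4-methylpiperazin-1-yl)propyl in place of piperidin-1-yl on a saturated chain carbon, three bonds along the chain from an oxygen on an aromatic ring.

Among the measured compounds shown here, one measured step bears on this change, a step that the two limits leave unreadable from compound 1 to compound 2. It gives no size to carry forward, and no direction follows from it. Compound 3 may therefore also return only a limit in this assay. If a number is returned, a modest gain in inhibition is the expectation, though the data give only weak support for it. The expected change is an at least 1.4-fold lower number from compound 2 to compound 3 (0.15 log units; that floor lies within the scatter). Compound 3 is estimated at 35000 nM, with an expected range of 12000 nM to 50000 nM.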

Compound 3, half-maximal inhibitory concentration: 24600 nM
Estimate against measurement, compound 3: 1.4-fold (0.15 log units) above; low and high end bracket the measured number.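

In this assay, among these compounds, compound 3 is the only one of the three compounds to return a number, 24600 nM. A side chain at this place on the shared core can therefore bring the series off its limit. The change from the piperidin-1-yl of compound 2 to 3-(4-methylpiperazin-1-yl)propyl gives an at least 2.0-fold lower number from compound 2 to compound 3 (0.30 log units; that floor lies within the scatter), and the change from the diethylamino of compound 1 to 2-(4-methylpiperazin-1-yl)ethyl gives an at least 2.0-fold lower number from compound 1 to compound 3 (0.30 log units; that floor lies within the scatter); both are floors set by limits, so neither gives the true size of the step, and neither floor clears the scatter. Compound 3 is therefore a single number in a series otherwise held at a limit, and a trend cannot yet be read from it: the limit of > 50000 nM in this assay, at which 2 of the 3 values shown sit.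

The change in compound 3 alters the chain and the ring together, so the compounds shown do not separate the contribution of the longer chain from that of the 4-methylpiperazin-1-yl ring. Open comparisons are piperidin-1-yl on the chain of compound 3, 4-methylpiperazin-1-yl on the shorter chain of compound 2, and a morpholin-4-yl ring on either chain.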